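The source may report more compounds than this note shows. Statements on the series, on what has been measured and on what is new or still open speak of the compounds shown alone.

In a functional assay on VCaP cells (Homo sapiens) for antiproliferative activity, read by CCK-8 assay, with a stated time of 6 days (on this read-out higher numbers stand for weaker inhibition and lower numbers for stronger inhibition), compound 1 `CCN(c1ccc(C#N)c(Cl)c1)c1cc(-c2ccccc2)ccc1C` gives > 30000 nM, which is a limit of the assay and not a number. For compound 2 `CCN(c1ccc(C#N)c(Cl)c1)c1cc(-c2cccs2)ccc1C` the result reads "not determined" (no result reported). Among the measured compounds shown here, compound 3 `CCN(c1ccc(C#N)c(Cl)c1)c1cc(-c2c[nH]nc2C)ccc1C` gives 3190 nM, the only true number so far, so it has no numerical neighbours to be ranked against. For the measured compounds named here, the one measured step is an at least 9.4-fold lower number from compound 1 to compound 3 (0.97 log units; beyond the scatter), where 3-methyl-1H-pyrazol-4-yl takes the place of phenyl. Its size rests on (the limit of > 30000 nM in this assay, at which 1 of the 3 values shown sits), so the real gap could be larger.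

Compound 4 `CCN(c1ccc(C#N)c(Cl)c1)c1cc(-n2cccn2)ccc1C` carries 1H-pyrazol-1-yl in place of 3-methyl-1H-pyrazol-4-yl on an aromatic carbon. The five-membered aromatic ring stays, but the group that came with an at least 9.4-fold lower number from compound 1 to compound 3 (0.97 log units; beyond the scatter) goes, so part of that gain is expected to be lost. With a single step as a guide, this expectation is loose. The estimated change is a 2.8-fold higher number from compound 3 to compound 4 (0.45 log units; beyond the scatter), towards a higher number and so weaker inhibition. For compound 4 the expected value is 9000 nM, with an estimated range of 3000 nM to 30000 nM.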

Compound 4, half-maximal inhibitory concentration: 2340 nM
Estimate against measurement, compound 4: 3.8-fold (0.59 log units) above; measured number outside the range, below it.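

In this assay, 1H-pyrazol-1-yl in place of 3-methyl-1H-pyrazol-4-yl gives a 1.4-fold lower number from compound 3 to compound 4 (0.13 log units; within the scatter) and so leaves the two groups indistinguishable here, even though the entering group has 0 hydrogen-bond donors and a ring joined through nitrogen rather than carbon. The advantage over phenyl therefore is not confined to one pyrazole: the change from phenyl to 1H-pyrazol-1-yl gives an at least 12-fold lower number from compound 1 to compound 4 (1.10 log units; beyond the scatter) and so matches the earlier step in direction. From the compounds shown here alone, compound 1 gives > 30000 nM as a limit of the assay and not a number, so the size of that step stays open: (the limit of > 30000 nM in this assay, at which 1 of the 4 values shown sits).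

Whether an aromatic ring is needed at this place remains open, as no morpholine or simple amine appears among the compounds shown. It is also unknown how 1H-imidazol-1-yl, with its nitrogen atoms arranged differently, would compare.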